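Trimming a Spirocyclic Amide to a Cyclobutyl Amide

The source may report more compounds than this note shows. Statements on the series, on what has been measured and on what is new or still open speak of the compounds shown alone.

Compound 1 `C(#Cc1nc2c(s1)CN(C1CCCCC1)CC2)c1ccccc1` gives in an assay on HEK293 cells for positive allosteric modulation of metabotropic glutamate receptor 5 (Homo sapiens), read by FLIPR, with a stated time of 1 h (a lower number here means that less compound is needed, a higher number that more compound is needed for the effect), only a limit, > 10000 nM.
Compound 2 `CC(=O)N1CCc2nc(C#Cc3ccccc3)sc2C1` gives in this assay only a limit, > 10000 nM.
Compound 3 `O=C(C1CC12CCC2)N1CCc2nc(C#Cc3ccccc3)sc2C1` gives in this assay 3.9 nM.

Within the data shown here, compound 3 holds the only real number here; the other two sit at the limit of the assay (the limit of > 10000 nM in this assay, at which 2 of the 3 values shown sit). Compound 4 `O=C(C1CCC1)N1CCc2nc(C#Cc3ccccc3)sc2C1` differs from it by a group of 4 heavy atoms (4 carbon; one four-membered non-aromatic ring of carbon only) in place of a group of 6 heavy atoms (6 carbon; one three-membered non-aromatic ring of carbon only, one four-membered non-aromatic ring of carbon only), on a carbonyl carbon. The step that bears on this is an at least 2500-fold lower number from compound 2 to compound 3 (3.40 log units; beyond the scatter), where the same position went from a single carbon to the spirocycle. Cyclobutyl lies between those two in size, so some loss against compound 3 is expected, though far less than the distance to compound 2. The expected step is a 5.1-fold higher number from compound 3 to compound 4 (0.71 log units; beyond the scatter). Compound 4 is estimated at 20 nM, within 4 nM to 300 nM.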

Compound 4, half-maximal effective concentration: > 10000 nM
Compound 4: a limit, no number; the forecaster's own chance of this, stated with the estimate: 10%; middle value at least 500-fold (2.69 log units) from the limit.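

Swapping the spirocyclic group for cyclobutyl on the carbonyl carbon gives an at least 2500-fold higher number from compound 3 to compound 4 (3.40 log units; beyond the scatter), so a four-membered ring on that carbon is not enough on its own to keep the activity of compound 3. The steps from compound 1 and from compound 2 to compound 4 cannot be read, as both ends are limits. Only compound 3 carries a real number: the limit of > 10000 nM in this assay, at which 3 of the 4 values shown sit.

Going by these compounds, whether a cyclopentyl or a cyclohexyl on the same carbonyl carbon would recover any activity stays open. So does whether a spirocycle is needed at all.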